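A few compounds are considered here, and "the series" means these few. Any claim that something is new, unique, unknown or untested is made for them only; others in the source may bear on it.

Measured so far in a functional assay on CEM-DNR-bulk cells (Homo sapiens), read by MTT assay, with a stated time of 72 h; a lower number here means a stronger inhibitor, a higher number a weaker inhibitor:
- Compound 1 `CSc1ncnc2c1c(-c1ccsc1)cn2[C@@H]1O[C@H](CO)[C@@H](O)[C@H]1O`: > 20000 nM, a limit of the assay
- Compound 2 `C#Cc1cn([C@@H]2O[C@H](CO)[C@@H](O)[C@H]2O)c2ncnc(SC)c12`: 110 nM

For the measured compounds named here, compound 2 holds the only actual number in this assay. The reading for compound 1 is a limit, and the limit of > 20000 nM in this assay, at which 1 of the 2 values shown sits, is all that the data give on it.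

Compound 3 `C#Cc1cn([C@@H]2O[C@H](CO)[C@@H](O)[C@H]2O)c2ncnc(NC)c12` keeps the ethynyl group of compound 2. It differs by methylamino in place of methylsulfanyl on an aromatic carbon, next to the ring nitrogen: methylamino in place of methylsulfanyl on an aromatic carbon.

Going by the values given here, only one measured step exists, an at least 180-fold lower number from compound 1 to compound 2 (2.25 log units; beyond the scatter). It is large, but it concerns the exchange of thiophen-3-yl for ethynyl at another place, so it shows how much that place matters and says nothing direct about the methylsulfanyl place. Among the compounds with values here, no measured step touches the new change. A modest rise in the number is therefore expected in this assay, held loosely, and a fall remains possible.

The step expected on this reasoning is a 2.3-fold higher number from compound 2 to compound 3 (0.36 log units; beyond the scatter). For compound 3 the estimated value is 250 nM, with an expected range of 40 nM to 2500 nM.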

Compound 3, half-maximal inhibitory concentration: 18500 nM
Compound 3: the middle estimate sits 74-fold (1.87 log units) below what was measured; the whole stated range lies below it.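

With the ethynyl group kept, methylamino in place of methylsulfanyl gives a 170-fold higher number from compound 2 to compound 3 (2.23 log units; beyond the scatter) in this assay, so the place on the aromatic carbon next to the ring nitrogen also matters strongly, and not only the place where ethynyl replaced thiophen-3-yl. The exchange is small by the computed count: methylsulfanyl and methylamino each have 2 heavy atoms, neither has a ring or a net charge, and methylamino carries 1 hydrogen-bond donor where methylsulfanyl has 0. For the compounds shown here, compound 3 still gives a measured number, whereas the only reading that is a limit of the assay belongs to compound 1: the limit of > 20000 nM in this assay, at which 1 of the 3 values shown sits.

The compounds shown do not tell whether the exchange of sulfur for nitrogen or the added hydrogen-bond donor goes with this step, and a single pair gives no trend at this place. They also leave open how a methoxy group, an unsubstituted amine or a longer chain such as ethylsulfanyl would read here, and whether the same step would appear with thiophen-3-yl in place of ethynyl.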